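The compounds below may be only part of what the source reports. "The series", "measured", "known", "first", "only" and "open" are said of these compounds alone.

In an ADME assay on GES1 cells (Homo sapiens) for cytotoxicity, read by MTT assay, with a stated time of 24 h (a higher number here means that more compound is tolerated, a lower number that less compound is tolerated), the compounds are compared by how much of each a cell culture tolerates. Compound 1 `Cc1ccccc1-n1cc(-c2cccc(NS(=O)(=O)c3c[nH]c(=O)[nH]c3=O)c2)nn1` gives 21500 nM. Compound 2 `Cc1cccc(-n2cc(-c3cccc(NS(=O)(=O)c4c[nH]c(=O)[nH]c4=O)c3)nn2)c1` gives 18500 nM, and the step of a 1.2-fold lower number from compound 1 to compound 2 (0.07 log units; within the scatter) shows that moving the methyl group around the ring made no difference that stands out from repeated measurements. Compound 3 `O=c1[nH]cc(S(=O)(=O)Nc2cccc(-c3cn(-c4cccc(F)c4)nn3)c2)c(=O)[nH]1` gives "not toxic" (no number reported), so no single number fixes where it stands; all that is known is that no toxicity was seen in this assay. Compound 4 `O=c1[nH]cc(S(=O)(=O)Nc2cccc(-c3cn(-c4cccc(Cl)c4)nn3)c2)c(=O)[nH]1` differs from compound 3 by chloro in place of fluoro on an aromatic carbon. Among the measured compounds shown here, the only measured step concerns a different part of the molecule and a different change, and it was within the scatter; nothing measured here speaks for a large shift when one halogen replaces another. For compound 4 a number close to or above those of compound 1 and compound 2 is therefore expected, with the real chance that again only "not toxic" is reported. The estimate for compound 4 in this assay is 30000 nM, within a range from 10000 nM to 100000 nM.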

Compound 4, half-maximal cytotoxic concentration: 26200 nM
Compound 4: the middle estimate sits 1.1-fold (0.06 log units) above what was measured; measured number inside the range.
By their numbers in this assay, from the lowest: compounds 2, 1 and 4 (each within the scatter of the next).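

In this assay, setting the chloro compound against one methyl compound shows a 1.4-fold higher number from compound 2 to compound 4 (0.15 log units; within the scatter), and setting it against the other methyl compound shows a 1.2-fold higher number from compound 1 to compound 4 (0.09 log units; within the scatter). Neither step stands out from repeated measurements, so at this place on the ring, the chloro compound cannot be told apart from the two methyl compounds in this assay. The step from fluoro to chloro cannot be read, since compound 3 has the words "not toxic" and no number to compare.

From the compounds shown here alone, whether a different group here, such as an amine, a methoxy group or a carboxylic acid, would move the number beyond the scatter remains open. No measurement shown here offers an explanation for these numbers.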